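Trimming the sulfonamide chain: compound 2 to compound 4

The source may report more compounds than this note shows. Statements on the series, on what has been measured and on what is new or still open speak of the compounds shown alone.

Measured compounds:
- compound 1, `CCC1C(=O)N(C)c2cnc(Nc3ccc(S(=O)(=O)NCCCO)cc3)nc2N1c1ccn(C)n1`: 48900 nM
- compound 2, `CCCCNS(=O)(=O)c1ccc(Nc2ncc3c(n2)N(c2ccn(C)n2)C(CC)C(=O)N3C)cc1`: 10600 nM
- compound 3, `CCC1C(=O)N(C)c2cnc(-n3ccc4cc(C(=O)NCC(C)C)ccc43)nc2N1c1ccn(C)n1`: 19200 nM

In a functional assay on A549 cells (Homo sapiens) for antiproliferative activity, read by CCK-8 assay, with a stated time of 72 h (on this read-out higher numbers stand for weaker inhibition of growth and lower numbers for stronger inhibition of growth), compound 2 gives the lowest of the three numbers. Compound 3 sits close to it, within the scatter, so no order between compound 2 and compound 3 can be read from these two values. Compound 1 stands apart: the step of a 4.6-fold lower number from compound 1 to compound 2 (0.66 log units; beyond the scatter) is beyond the scatter.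

Compound 4, `CCCNS(=O)(=O)c1ccc(Nc2ncc3c(n2)N(c2ccn(C)n2)C(CC)C(=O)N3C)cc1`, differs from compound 2 in one place: hydrogen in place of methyl on a saturated chain carbon, three bonds along the chain from a sulfonamide nitrogen. For the measured compounds named here, the only measured step at this place is the one from compound 1 to compound 2, and it concerns a different pair of groups, a hydroxy swapped for a methyl, not the loss of a methyl for hydrogen. It therefore bears only loosely on the present change, and nothing among the shown compounds tests a shortening of this chain by one carbon. The step is expected to be small, a 1.3-fold higher number from compound 2 to compound 4 (0.12 log units; within the scatter), most likely within the scatter, with a slight lean toward a higher number. Compound 4 is thus estimated at 14000 nM, with a range from 6000 nM to 35000 nM in this assay.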

Compound 4, concentration for 50% growth inhibition: 15000 nM
Beside the measured number, compound 4's estimate is 1.1-fold (0.03 log units) below it, within the range that was stated.
By their numbers in this assay, from the lowest: compounds 2, 4 and 3 (each within the scatter of the next); then compound 1.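

In this assay, the change of butyl to propyl gives a 1.4-fold higher number from compound 2 to compound 4 (0.15 log units; within the scatter), so at this place the chain can lose a methyl with no readable difference in growth inhibition. With hydrogen in place of hydroxy, the result is a 3.3-fold lower number from compound 1 to compound 4 (0.51 log units; beyond the scatter), which shows that compound 1 stands apart from compound 4 as well as from compound 2: among these three compounds, the hydroxy goes with the higher number whether methyl or hydrogen replaces it. No evidence at hand explains either step.

The compounds shown leave open whether a shorter chain such as ethyl, or a longer one such as pentyl, would stay within the scatter of compound 2 and compound 4. They also leave open whether an amine or a carboxylic acid at this carbon would go with a higher number, as the hydroxy does.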